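Swapping the amide aryl group on a dopamine receptor ligand

A few compounds are considered here, and "the series" means these few. Any claim that something is new, unique, unknown or untested is made for them only; others in the source may bear on it.

Measured compounds:
- compound 1 `CCCN(CC[C@H]1CC[C@H](NC(=O)/C=C/c2ccc(Cl)cc2)CC1)[C@H]1CCc2nc(N)sc2C1` gives 2.5 nM
- compound 2 `CCCN(CC[C@H]1CC[C@H](NC(=O)/C=C/c2ccccc2Cl)CC1)[C@H]1CCc2nc(N)sc2C1` gives 1.2 nM
- compound 3 `CCCN(CC[C@H]1CC[C@H](NC(=O)c2cccc3cnccc23)CC1)[C@H]1CCc2nc(N)sc2C1` gives 5.9 nM

These three compounds share a common core and differ only in the group attached to the amide carbonyl. They were tested in an assay on brain for displacement of a labelled ligand from D(3) dopamine receptor (Rattus norvegicus); on this read-out higher numbers stand for weaker inhibition and lower numbers for stronger inhibition. Compound 3 has the highest number of the three: the step of a 2.4-fold higher number from compound 1 to compound 3 (0.37 log units; beyond the scatter) and the step of a 4.9-fold higher number from compound 2 to compound 3 (0.69 log units; beyond the scatter) both run upward, so the isoquinolin-5-yl amide binds less tightly than either chlorophenyl-ethenyl amide. Between the two chlorophenyl-ethenyl amides the step of a 2.1-fold lower number from compound 1 to compound 2 (0.32 log units; beyond the scatter) is modest.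

Compound 4 `CCCN(CC[C@H]1CC[C@H](NC(=O)c2ccc(-n3cccn3)cc2)CC1)[C@H]1CCc2nc(N)sc2C1` has not yet been measured. It differs from compound 3 in one place: 4-(1H-pyrazol-1-yl)phenyl in place of isoquinolin-5-yl on a carbonyl carbon. Among the compounds with values here, none of the measured steps involves this new group, so the only guide is that changing the amide aryl group has so far moved this assay by modest amounts, and that compound 3 sits at the weak end of the range. A flat six-membered ring bearing a second aromatic ring is closer in shape to the groups of compounds 1 and 2 than to compound 3, so a modest downward step is expected, estimated as a 1.7-fold lower number from compound 3 to compound 4 (0.23 log units; within the scatter). For compound 4 the estimated value is 3.5 nM, with a likely range from 1.2 nM to 10 nM.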

Compound 4, inhibition constant: 3 nM
For compound 4 the middle estimate is 1.2-fold (0.07 log units) above the measured one; low and high end bracket the measured number.
By their numbers in this assay, from the lowest: compound 2; then compounds 1, 4 and 3 (each within the scatter of the next, the first and the last beyond it).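

In this assay, putting 4-(1H-pyrazol-1-yl)phenyl in place of isoquinolin-5-yl on the carbonyl carbon gives a 2.0-fold lower number from compound 3 to compound 4 (0.29 log units; within the scatter) and so cannot be told apart from repeat measurement. The new result shows that this place tolerates an aryl group with neither a chlorine nor an ethenyl chain: the comparison with the 2-(4-chlorophenyl)ethenyl amide gives a 1.2-fold higher number from compound 1 to compound 4 (0.08 log units; within the scatter) and also lies inside the scatter, while the 2-(2-chlorophenyl)ethenyl amide remains separate, with a 2.5-fold higher number from compound 2 to compound 4 (0.40 log units; beyond the scatter) as a modest step. No measurement shown here offers an explanation for these numbers.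

The compounds shown leave open how much the pyrazole ring itself contributes, as a plain phenyl amide would be needed to separate that ring from the benzene ring carrying it. Also open, as far as these compounds go, is how this place responds to a group without an aromatic ring, such as cyclohexyl, or to one carrying a charge-bearing substituent, such as an amine or a carboxylic acid.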